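Same swap to methylsulfonyl on a second core

The compounds below may be only part of what the source reports. "The series", "measured", "known", "first", "only" and "open" are said of these compounds alone.

Compound 1 `Cn1c(-c2ccccc2F)nnc1[S+](C)[O-]` and compound 2 `Cn1c(-c2ccccc2F)nnc1S(C)(=O)=O` share one core; compound 3 `Cn1nc(-c2ccccc2)nc1[S+](C)[O-]` and the not yet measured compound 4 `Cn1nc(-c2ccccc2)nc1S(C)(=O)=O` share another. The difference between the two cores is not broken down here.

In a functional assay on the whole organism for antagonist activity, with Mus musculus as the target (on this read-out lower numbers stand for an effect already at smaller amounts and higher numbers for an effect only at larger amounts of compound), compound 1 gives 20 mg/kg. In this assay compound 2 gives 17.6 mg/kg. The change between them, (a group of 4 heavy atoms (1 carbon, 2 oxygen, 1 sulfur; no ring) in place of a group of 3 heavy atoms (1 carbon, 1 oxygen, 1 sulfur; no ring), on an aromatic carbon), gives the step of a 1.1-fold lower number from compound 1 to compound 2 (0.06 log units; within the scatter).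

In this assay compound 3 reaches only a limit, > 200 mg/kg, and no number. That is the limit of > 200 mg/kg in this assay, at which 1 of the 3 values shown sits.

Compound 4 carries the same kind of change on its own core, (a group of 4 heavy atoms (1 carbon, 2 oxygen, 1 sulfur; no ring) in place of a group of 3 heavy atoms (1 carbon, 1 oxygen, 1 sulfur; no ring), on an aromatic carbon). The surroundings are not word for word the same: on each core the place lies two ring bonds from a ring atom that bears a larger group, and that group differs between the core of compound 1 and the core of compound 3, as the two counted differences show.

For compound 4 the step that the limit leaves unreadable from compound 3 to compound 4 is expected to be small, resting on the step of a 1.1-fold lower number from compound 1 to compound 2 (0.06 log units; within the scatter), which sits within the scatter. Since compound 3 stands at the limit > 200 mg/kg, compound 4 is expected to sit at or beyond the same limit as well, and a numerical value may again not be reached. The estimate for compound 4 in this assay is 300 mg/kg, with a range from 120 mg/kg to 1000 mg/kg.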

Compound 4, dose for half-maximal effect: > 200 mg/kg
Compound 4: a limit, no number; the forecaster's own chance of this, stated with the estimate: 75%; the middle value is on the limit's open side.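

In this assay compound 4 gives > 200 mg/kg, a limit and not a number. Compound 3 stands at the same limit, so no step from compound 3 to compound 4 can be read: the limit of > 200 mg/kg in this assay, at which 2 of the 4 values shown sit.

The compounds shown leave open whether methylsulfonyl in place of the previous group has any effect on the core of compound 3, as neither compound 3 nor compound 4 has a number.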